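Saturated fatty acid amides: morpholine to pyrrolidine swap

The source may report more compounds than this note shows. Statements on the series, on what has been measured and on what is new or still open speak of the compounds shown alone.

Measured so far:
- compound 1, `CCCCCCCCCCCCCCCCCC(=O)N1CCOCC1`: 53.1 ug/mL
- compound 2, `CCCCCCCC/C=C\CCCCCCCC(=O)N1CCCC1`: 45.6 ug/mL

In a functional assay on NCI-H460 cells (Homo sapiens) for antiproliferative activity, read by sulforhodamine B assay, with a stated time of 48 h (on this read-out higher numbers stand for weaker inhibition of growth and lower numbers for stronger inhibition of growth), compound 1 gives 53.1 ug/mL, the highest of the two numbers in hand. Compound 2, `CCCCCCCC/C=C\CCCCCCCC(=O)N1CCCC1`, gives 45.6 ug/mL in this assay; the two values sit within the scatter of each other, so no order between them can be read. Compound 2 differs from compound 1 in more than one place, so its value says only that a pyrrolidin-1-yl amide on an unsaturated chain lands in the same weak range.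

The next compound, compound 3, `CCCCCCCCCCCCCCCCCC(=O)N1CCCC1`, keeps the saturated chain of compound 1 and carries the change (pyrrolidin-1-yl in place of morpholin-4-yl on a carbonyl carbon). Among the measured compounds shown here, no measured pair isolates this change. With both values in hand lying together, compound 3 is expected to stay in the same range, with a step of a 1.1-fold lower number from compound 1 to compound 3 (0.03 log units; within the scatter) that is expected to be none beyond the scatter.

Compound 3 is thus estimated at 50 ug/mL in this assay, within 25 ug/mL to 100 ug/mL.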

Compound 3, concentration for 50% growth inhibition: 10.8 ug/mL
The estimate for compound 3 lay 4.6-fold (0.67 log units) above the measured number, and the stated range ends above it.
By their numbers in this assay, from the lowest: compound 3; then compounds 2 and 1 (each within the scatter of the next).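

In this assay pyrrolidin-1-yl in place of morpholin-4-yl on a carbonyl carbon gives a 4.9-fold lower number from compound 1 to compound 3 (0.69 log units; beyond the scatter) and so shows that, with the saturated chain held fixed, this position does move the read-out, which the two earlier values lying together could not show. The change takes away one ring member and one hetero atom together, and this single pair cannot separate the two. Nothing measured here accounts for the step.

As far as these compounds go, compound 2 carries the same pyrrolidin-1-yl on an unsaturated chain and gives 45.6 ug/mL on this read-out, so whether the step holds on chains other than the saturated one remains open. Also open, from the compounds shown here alone, is whether a piperidin-1-yl ring or an open diethylamino group on the same carbonyl carbon would read like pyrrolidin-1-yl or like morpholin-4-yl.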